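The source may hold more compounds than are shown below. What is called first, only, known or untested is meant among the compounds shown, and "the series" means these compounds.

Measured so far in a functional assay (aorta) with Rattus norvegicus as the target; a lower number here means that less compound is needed, a higher number that more compound is needed for the effect:
- compound 1 `C/N=C(/S)C1=CC(C)(C)Oc2ccc([N+](=O)[O-])cc21`: 1.35 nM
- compound 2 `CC1(C)C=C(/C(S)=N\CCC#N)c2cc([N+](=O)[O-])ccc2O1`: 0.372 nM

Compound 2 holds the lower of the two numbers, so less of it is needed for the effect. Among the compounds with values here, the only measured step, a 3.6-fold lower number from compound 1 to compound 2 (0.56 log units; beyond the scatter), puts cyanomethyl in place of hydrogen on a saturated chain carbon bound to a double-bonded nitrogen.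

Compound 3 `CC1(C)C=C(C(=O)NCCC#N)c2cc([N+](=O)[O-])ccc2O1` is changed elsewhere: a group of 7 heavy atoms (4 carbon, 2 nitrogen, 1 oxygen; no ring) in place of a group of 7 heavy atoms (4 carbon, 2 nitrogen, 1 sulfur; no ring), on a double-bonded ring carbon. The sulfur-containing group leaves and (2-cyanoethyl)carbamoyl enters, on a double-bonded ring carbon. Within the data shown here, no measured pair tests this exchange of sulfur for oxygen, so the step from compound 1 bears on it only loosely. It shows that one change in this small set can move the number beyond the scatter, but it gives no direction for this exchange.

Starting from the low value of compound 2, a rise is more likely than a further fall, though this is a cautious expectation. The expected change is an 8.1-fold higher number from compound 2 to compound 3 (0.91 log units; beyond the scatter). For compound 3 the estimated value is 3 nM, with an expected range from 0.3 nM to 30 nM.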

Compound 3, half-maximal effective concentration: 2.82 nM
Estimate against measurement, compound 3: 1.1-fold (0.03 log units) above; low and high end bracket the measured number.
By their numbers in this assay, from the lowest: compound 2; then compound 1; then compound 3.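

In this assay, replacing the sulfur-containing group on the double-bonded ring carbon with (2-cyanoethyl)carbamoyl gives a 7.6-fold higher number from compound 2 to compound 3 (0.88 log units; beyond the scatter), so this position responds to an exchange of sulfur for oxygen even though the heavy-atom count of the group stays the same. The wider change at the same carbon gives a 2.1-fold higher number from compound 1 to compound 3 (0.32 log units; beyond the scatter), which means the nitrile-bearing chain does not by itself bring a lower number: it appears in both compound 2, with the lowest number of the three, and compound 3, with the highest. Nothing available here accounts for the difference between these two groups.

From the compounds shown here alone, it remains open whether an amide with a plain methyl on its nitrogen would sit above compound 1 as compound 3 sits above compound 2, which would test the sulfur-for-oxygen exchange on a second chain. Also open, going by these compounds, is how a longer chain ending in a nitrile, or a carboxylic acid in place of the nitrile, would behave at this ring carbon.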